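Cytotoxicity notes: cyclobutyl ether to oxetanyl cyclohexyl ether

The source may hold more compounds than are shown below. What is called first, only, known or untested is meant among the compounds shown, and "the series" means these compounds.

Measured compounds:
- compound 1 `CC(C)(C)C#Cc1cc(N(C(=O)[C@H]2CC[C@H](C)CC2)[C@H]2C[C@@H](Oc3cccnc3)C2)c(C(=O)O)s1`: > 20000 nM in an ADME assay on MT4 cells (Homo sapiens) for cytotoxicity, with a stated time of 5 days; a lower number here means that less compound is tolerated, a higher number that more compound is tolerated (a limit of the assay)
- compound 2 `CC(C)(C)C#Cc1cc(N(C(=O)[C@H]2CC[C@H](C)CC2)[C@H]2CC[C@@H](Oc3ccc(=O)[nH]n3)CC2)c(C(=O)O)s1`: in this assay compound 2 gives > 20000 nM (a limit of the assay)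

Both measured values sit at the upper limit of this assay, so neither compound has a numerical read-out; compound 1 stands at the limit of > 20000 nM in this assay, at which 2 of the 2 values shown sit, together with compound 2. Within the data shown here, no step between measured compounds is available, so nothing about the effect of a change at the amide-type nitrogen has been quantified.

Compound 3 `CC(C)(C)C#Cc1cc(N(C(=O)[C@H]2CC[C@H](C)CC2)[C@H]2CC[C@H](OC3COC3)CC2)c(C(=O)O)s1` differs from compound 1 by 4-((oxetan-3-yl)oxy)cyclohexyl in place of 3-((pyridin-3-yl)oxy)cyclobutyl on an amide-type nitrogen. Given that compound 1 and compound 2 both sit at the limit, the expectation for compound 3 is no step beyond the scatter, and most likely again only a limit; the step from compound 1 is estimated as a step that the limit leaves unreadable from compound 1 to compound 3. Compound 3 is expected to give about 30000 nM, within the range 15000 nM to 100000 nM.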

Compound 3, half-maximal cytotoxic concentration: > 20000 nM
Compound 3 ended at the assay's limit; the forecaster's own chance of this, stated with the estimate: 85%; the middle value lies beyond the limit too.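

In this assay, compound 1 and compound 3 both end at a limit of the assay, so no step between them can be read: the limit of > 20000 nM in this assay, at which 3 of the 3 values shown sit.

The compounds shown leave open whether 4-((oxetan-3-yl)oxy)cyclohexyl in place of 3-((pyridin-3-yl)oxy)cyclobutyl on the amide-type nitrogen changes the cytotoxic concentration at all.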